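Working notes on the aryl-pyrazole amine series

This account rests on a few compounds, and the source may have more. Where it says the series, first, only, none or still open, it means among the compounds named here.

Measured compounds:
Compound 1 `Cc1ccc(-c2n[nH]cc2N2CCCNCC2)cc1` – in an assay on isolated protein for binding affinity to 5-hydroxytryptamine receptor 4 (Homo sapiens) (on this read-out higher numbers stand for weaker inhibition and lower numbers for stronger inhibition), compound 1 gives only a limit, > 10000 nM.
Compound 2 `c1ccc(-c2n[nH]cc2N2CCCNCC2)cc1` – in this assay compound 2 gives only a limit, > 10000 nM.
Compound 3 `COc1ccc(-c2n[nH]cc2N2CCNCC2)cc1` – in this assay compound 3 gives only a limit, > 10000 nM.

Compound 3 thus stands at the assay limit, as do the other two members, since (the limit of > 10000 nM in this assay, at which 3 of the 3 values shown sit). For the measured compounds named here, the only pairwise step, a step that the two limits leave unreadable from compound 1 to compound 2, is hidden behind the two limits and gives no readable size. Compound 4 `Clc1ccc(-c2n[nH]cc2N2CCNCC2)cc1` differs from compound 3 by chloro in place of methoxy on an aromatic carbon. Going by the values given here, no measured step informs this change, and nothing has yet returned a number in this assay. Compound 4 is therefore expected to remain at or near the limit, with an estimated step that the limit leaves unreadable from compound 3 to compound 4. The estimate for compound 4 in this assay is 15000 nM, ranging from 4000 nM to 60000 nM.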

Compound 4, inhibition constant: > 10000 nM
Compound 4: a limit, no number; the forecaster's own chance of this, stated with the estimate: 80%; the middle value lies beyond the limit too.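

In this assay compound 4 gives only a limit, > 10000 nM, and compound 3 is also a limit, so no step can be read between them. The compounds shown leave open what affinity, if any, lies beyond that limit.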